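The source may report more compounds than this note shows. Statements on the series, on what has been measured and on what is new or still open speak of the compounds shown alone.

Measured so far:
compound 1, `Cc1c(C)n([C@H](C)c2ccccc2)c2ncnc(N[C@H](C)c3ccccc3)c12`: 2650 nM
compound 2, `Cc1c(C)n([C@H](C)c2ccccc2)c2nc(-c3ccccc3)nc(O)c12`: 2980 nM

For the measured compounds named here, both compounds have been tested in an assay for binding affinity to adenosine receptor A1 (Rattus norvegicus), read by radioligand binding; a higher number here means a weaker inhibitor, a lower number a stronger inhibitor. Compound 2 gives 2980 nM, the higher of the two numbers, while compound 1 gives 2650 nM; the gap between them is within the usual scatter of this assay, so the two cannot be told apart on the numbers shown.

Compound 3, `Cc1c(C)n([C@@H](C)c2ccccc2)c2nc(-c3ccccc3)nc(O)c12`, has not yet been measured. It is drawn with the same atoms and bonds as compound 2: the two compounds have the same atoms and bonds and differ only in configuration as drawn: 1 of 1 stereo elements differ; a stereocentre at a saturated chain carbon is drawn R in compound 2 and S in compound 3. Going by the values given here, no measured pair in this set differs only in configuration at that stereocentre, so there is no step from which to read the size of this change. Inversion of a single stereocentre can leave binding unchanged or shift it either way, and nothing here settles which.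

Compound 3 is therefore estimated to give 5000 nM, with a range from 1500 nM to 20000 nM. The step of a 1.7-fold higher number from compound 2 to compound 3 (0.22 log units; within the scatter) implied by this estimate is expected to be modest, towards a weaker inhibitor, and may well not exceed the scatter.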

Compound 3, inhibition constant: > 30000 nM
Compound 3: only a limit was reported; the forecaster's own chance of this, stated with the estimate: 20%; middle value at least 6.0-fold (0.77 log units) from the limit.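

For the compounds shown here, until now no measured pair isolated the stereocentre at the saturated chain carbon, so nothing showed whether configuration there mattered. In this assay, changing that stereocentre from R as drawn to S gives an at least 10-fold higher number from compound 2 to compound 3 (1.00 log units; beyond the scatter), which shows that binding at this position is sensitive to configuration, with the R form as drawn the stronger of this pair. The entry for compound 3, > 30000 nM, is a limit of the assay and not a number. The step can be set on the configuration alone, as nothing else in the structure changes: the fact that compounds 2 and 3 differ only in the configuration as drawn

This is the only inverted pair among the compounds shown, so it remains open how far the step really reaches and whether the same inversion would give a step of similar size on compound 1, which carries the second stereocentre in its amine side chain. Also open, as far as these compounds go, is whether an ethyl chain or a carboxylic acid at that stereocentre would keep the same sensitivity to configuration.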